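Swapping chloro for fluoro on compound 2

The compounds below may be only part of what the source reports. "The series", "measured", "known", "first", "only" and "open" are said of these compounds alone.

Compound 1 `CCCCNc1cccc(N2C[C@@H](c3ccc(OC)c(OC4CCCC4)c3)CC2=O)c1`: > 10000 nM
Compound 2 `COc1ccc([C@H]2CC(=O)N(c3cccc(NS(=O)(=O)c4cccc(Cl)c4)c3)C2)cc1OC1CCCC1`: > 10000 nM

Both compounds were measured in a functional assay on HEK293 cells (Homo sapiens) for cytotoxicity; a lower number here means that less compound is tolerated, a higher number that more compound is tolerated. Compound 1 gives > 10000 nM, which is a limit of the assay and not a number. Compound 2 gives > 10000 nM, which is likewise a limit and not a number. The two therefore stand at one and the same place: the limit of > 10000 nM in this assay, at which 2 of the 2 values shown sit.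

Among the measured compounds shown here, the only measured step is a step that the two limits leave unreadable from compound 1 to compound 2, with (3-chlorophenyl)sulfonyl in place of butyl on a nitrogen on an aromatic ring. It offers no size to carry forward.

Compound 3 `COc1ccc([C@H]2CC(=O)N(c3cccc(NS(=O)(=O)c4cccc(F)c4)c3)C2)cc1OC1CCCC1` comes from compound 2 by a single change, (fluoro in place of chloro on an aromatic carbon), with fluoro in place of chloro on an aromatic carbon. For the measured compounds named here, no measured step covers this exchange. Compound 2 is the nearest reference, and its > 10000 nM is a limit, so no step beyond the scatter is expected in this assay, in either direction, and another limit is the likeliest report. The expected step is a step that the limit leaves unreadable from compound 2 to compound 3. For compound 3 the estimated value is 14000 nM, with an expected range from 7000 nM to 30000 nM.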

Compound 3, half-maximal cytotoxic concentration: > 10000 nM
Compound 3 ended at the assay's limit; the forecaster's own chance of this, stated with the estimate: 85%; the middle value lies beyond the limit too.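

In this assay compound 3 gives > 10000 nM, which is a limit of the assay and not a number, so its steps from compound 1 and compound 2 cannot be read, and no new step emerges: the limit of > 10000 nM in this assay, at which 3 of the 3 values shown sit.

The compounds shown leave open at what concentration compound 1, compound 2 or compound 3 becomes cytotoxic, and whether the three differ at all.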